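Removing the ring methyl from compound 2

The compounds below may be only part of what the source reports. "The series", "measured", "known", "first", "only" and "open" are said of these compounds alone.

Three compounds of the shared core have numbers in an assay on cells for inhibition of Amine oxidase [flavin-containing] A (Homo sapiens), read by fluorescence and Amplex Red, with a stated time of 15 min; on this read-out lower numbers stand for stronger inhibition and higher numbers for weaker inhibition. Compound 1 `Cc1ccc2oc(-c3ccccc3Br)cc2c1` gives 11000 nM; compound 2 `Cc1cccc2cc(-c3ccccc3Br)oc12` gives 100000 nM; compound 3 `Brc1cccc(-c2cc3ccccc3o2)c1` gives 100000 nM. Compound 2 stands level with compound 3 at the digits shown, the two together the highest of the three, and furthest from compound 1, whose number is markedly lower. Compound 4 `Brc1ccccc1-c1cc2ccccc2o1` follows from compound 2 by the change (hydrogen in place of methyl on an aromatic carbon), the site being ortho to a fused ring and meta to a fused ring. Among the measured compounds shown here, no step of this kind stands among the measured compounds. The methyl in compound 2 seems unhelpful, so a modest move toward lower numbers is expected, with compound 4 estimated at 30000 nM within 8000 nM to 100000 nM, a step of a 3.3-fold lower number from compound 2 to compound 4 (0.52 log units; beyond the scatter).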

Compound 4, half-maximal inhibitory concentration: 8120 nM
Compound 4: the middle estimate sits 3.7-fold (0.57 log units) above what was measured; the range from low to high includes it.
By their numbers in this assay, from the lowest: compounds 4 and 1 (each within the scatter of the next); then compounds 2 and 3 (each within the scatter of the next).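

In this assay, hydrogen in place of methyl at this site gives a 12-fold lower number from compound 2 to compound 4 (1.09 log units; beyond the scatter), so a methyl ortho to a fused ring and meta to a fused ring is clearly unfavourable in compound 2. The same replacement at the methyl site of compound 1 gives a 1.4-fold lower number from compound 1 to compound 4 (0.13 log units; within the scatter), so the loss is tied to the site in compound 2 and does not follow from a methyl on the core in general. No measurement bearing on the reason for this difference is available.
From the compounds shown here alone, it remains open whether any substituent is tolerated at the compound 2 site or only hydrogen. A fluorine, a methoxy group or an amine there would test this.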